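Varying the Sulfonamide Nitrogen Substituent in a Thiourea Series

The source may report more compounds than this note shows. Statements on the series, on what has been measured and on what is new or still open speak of the compounds shown alone.

compound 1 `NS(=O)(=O)c1ccc(N/C(S)=N\c2ccnc3cc(C(F)(F)F)ccc23)cc1` — 36600 nM
compound 2 `Cc1noc(NS(=O)(=O)c2ccc(N/C(S)=N\c3ccnc4cc(C(F)(F)F)ccc34)cc2)c1C` — 34000 nM
compound 3 `O=S(=O)(Nc1nccs1)c1ccc(N/C(S)=N\c2ccnc3cc(C(F)(F)F)ccc23)cc1` — 27200 nM

All three were measured in a functional assay on AS49-RAW cells (Homo sapiens) for antiproliferative activity, read by sulforhodamine B assay, with a stated time of 48 h; a lower number here means a stronger inhibitor, a higher number a weaker inhibitor. Compound 2 stands second highest of the three numbers, with compound 1 nearest (a 1.1-fold lower number from compound 1 to compound 2 (0.03 log units; within the scatter)) and compound 3 furthest (a 1.3-fold lower number from compound 2 to compound 3 (0.10 log units; within the scatter)); both steps lie within the scatter. Compound 4 `COc1ncnc(NS(=O)(=O)c2ccc(N/C(S)=N\c3ccnc4cc(C(F)(F)F)ccc34)cc2)c1OC` has not been measured; it differs from compound 2 by 5,6-dimethoxypyrimidin-4-yl in place of 3,4-dimethyl-1,2-oxazol-5-yl on a sulfonamide nitrogen. For the measured compounds named here, the steps that bear on this change are those that vary the group on the same sulfonamide nitrogen: a 1.1-fold lower number from compound 1 to compound 2 (0.03 log units; within the scatter), a 1.3-fold lower number from compound 1 to compound 3 (0.13 log units; within the scatter) and a 1.3-fold lower number from compound 2 to compound 3 (0.10 log units; within the scatter), none of them beyond the scatter. Compound 4 is therefore expected to show no step beyond the scatter in this assay. The estimate for compound 4 is 30000 nM, ranging from 12000 nM to 75000 nM, which would mean a 1.1-fold lower number from compound 2 to compound 4 (0.05 log units; within the scatter).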

Compound 4, half-maximal inhibitory concentration: 81800 nM
For compound 4 the middle estimate is 2.7-fold (0.44 log units) below the measured one, outside the stated range (above it).
By their numbers in this assay, from the lowest: compounds 3, 2 and 1 (each within the scatter of the next); then compound 4.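

For the compounds shown here, the sulfonamide nitrogen is not indifferent to its substituent in this assay: 5,6-dimethoxypyrimidin-4-yl is the first group here to give steps beyond the scatter, with a 2.4-fold higher number from compound 2 to compound 4 (0.38 log units; beyond the scatter), a 3.0-fold higher number from compound 3 to compound 4 (0.48 log units; beyond the scatter) and a 2.2-fold higher number from compound 1 to compound 4 (0.35 log units; beyond the scatter). All three steps are modest and run the same way, making compound 4 a weaker inhibitor than each of the other compounds. Left open is whether a phenyl group or a pyrimidin-4-yl group without methoxy groups on the same nitrogen would match compound 4 or the other compounds. No measurement offered here explains the change.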